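Chloro in Place of Methyl on the Aryl Ring

The source may report more compounds than this note shows. Statements on the series, on what has been measured and on what is new or still open speak of the compounds shown alone.

In an assay on HEK293 cells for positive allosteric modulation of metabotropic glutamate receptor 5 (Homo sapiens), read by FLIPR (on this read-out higher numbers stand for an effect only at larger amounts of compound and lower numbers for an effect already at smaller amounts), compound 1 `O=C(C1CCC(F)(F)CC1)N1CC(c2nc(-c3cccc(Cl)c3)no2)C1` gives 180 nM. Compound 2 `CC1CCC(C(=O)N2CC(c3nc(-c4cccc(Cl)c4)no3)C2)CC1` keeps the same core and in this assay compound 2 gives 1500 nM. For the measured compounds named here, the one measured step, an 8.3-fold higher number from compound 1 to compound 2 (0.92 log units; beyond the scatter), concerns the amide side of the shared core. Compound 3 `Cc1cccc(-c2noc(C3CN(C(=O)c4ccccc4F)C3)n2)c1` stands apart: in this assay compound 3 gives > 10000 nM, which is a limit of the assay and not a number. That limit, (the limit of > 10000 nM in this assay, at which 1 of the 3 values shown sits), is where compound 3 stands. Compound 4 `O=C(c1ccccc1F)N1CC(c2nc(-c3cccc(Cl)c3)no2)C1` differs from compound 3 in one place: chloro in place of methyl on an aromatic carbon. Going by the values given here, no measured step covers this exchange; the step of an 8.3-fold higher number from compound 1 to compound 2 (0.92 log units; beyond the scatter) alters a different part of the molecule and does not bear on it. What compounds 1 and 2 show is only that the 3-chlorophenyl is present in both compounds that returned a number. The expectation for compound 4 is therefore 8000 nM, estimated to lie between 2000 nM and 30000 nM. On these data alone, this amounts to an expected step of an at least 1.2-fold lower number from compound 3 to compound 4 (0.09 log units; that floor lies within the scatter), though with compound 3 at a limit the true size of that step remains open.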

Compound 4, half-maximal effective concentration: > 10000 nM
Compound 4 ended at the assay's limit; the forecaster's own chance of this, stated with the estimate: 50%; at least 1.2-fold (0.09 log units) between middle value and limit.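

In this assay compound 4 gives > 10000 nM, which is a limit and not a number, so the 3-chlorophenyl does not by itself return a number with a 2-fluorophenyl on the carbonyl: the limit of > 10000 nM in this assay, at which 2 of the 4 values shown sit.

Compound 3 and compound 4 both sit at a limit, and the step between them cannot be read. With the 3-chlorophenyl held constant, the group on the carbonyl makes a clear difference: 2-fluorophenyl in place of 4-methylcyclohexyl gives an at least 6.6-fold higher number from compound 2 to compound 4 (0.82 log units; beyond the scatter), and 2-fluorophenyl in place of 4,4-difluorocyclohexyl gives an at least 55-fold higher number from compound 1 to compound 4 (1.74 log units; beyond the scatter).

On these data alone, whether chloro and methyl differ at all remains open, and a 3-methylphenyl compound with the 4,4-difluorocyclohexyl on the carbonyl could test this with a readable number. The compounds shown also leave open how a methoxy group or a nitrile in place of chloro on this aromatic carbon would read.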